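The compounds below may be only part of what the source reports. "The series", "measured", "known", "first", "only" and "open" are said of these compounds alone.

Measured so far in a functional assay on CHO-K1 cells for antagonist activity at melanin-concentrating hormone receptor 1 (Homo sapiens), read by inositol phosphate accumulation, with stated times of 10 min and 45 min; on this read-out higher numbers stand for weaker inhibition and lower numbers for stronger inhibition:

Compound 1 `C/C(=C\C(=O)Nc1ccc2nc(N3CCC(O)CC3)nc(C)c2c1)c1ccc(Cl)cc1`: 227 nM
Compound 2 `Cc1nc(N2CCC(N3CCOC3=O)CC2)nc2ccc(NC(=O)/C=C/c3ccc(OC(F)(F)F)cc3)cc12`: 31 nM

Of the two compounds measured in this assay, compound 1 gives 227 nM and compound 2 gives 31 nM. Compound 2 thus stands at the lower of the two numbers, and its gap to compound 1 lies beyond the usual scatter, so compound 2 is the stronger inhibitor of the pair.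

Compound 3 `COCC(=O)NC1CCN(c2nc(C)c3cc(NC(=O)/C=C/c4ccc(OC(F)(F)F)cc4)ccc3n2)CC1` differs from compound 2 in one place: ((methoxymethyl)carbonyl)amino in place of 2-oxo-1,3-oxazolidin-3-yl on a saturated ring carbon. Among the measured compounds shown here, no pair of measured compounds shares this change, so nothing measured here speaks directly to its effect. Both groups carry the same count of heavy atoms and acceptors, and the only difference beyond the ring is the single added donor. The step from compound 2 to compound 3 is therefore expected to be small, at most a slight weakening, and likely within the scatter: a 1.5-fold higher number from compound 2 to compound 3 (0.16 log units; within the scatter). Compound 3 is expected to give about 45 nM, with a range from 15 nM to 150 nM.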

Compound 3, half-maximal inhibitory concentration: 14 nM
Compound 3: middle estimate off by 3.2-fold (0.51 log units), on the high side, and the stated range ends above it.
By their numbers in this assay, from the lowest: compound 3; then compound 2; then compound 1.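

In this assay, ((methoxymethyl)carbonyl)amino in place of 2-oxo-1,3-oxazolidin-3-yl on the saturated ring carbon gives a 2.2-fold lower number from compound 2 to compound 3 (0.35 log units; beyond the scatter), so this position keeps its inhibition, and modestly improves on it, when the ring is given up. As the only single-place comparison among the compounds shown, it also shows that the heavy-atom count stays the same while the ring goes and a hydrogen-bond donor enters. No available evidence accounts for this step. Going by these compounds, whether the lost ring or the added donor carries the step stays open, and an N-methyl amide at this place would separate the two. On these data alone, how far the methoxymethyl end matters also stays open, as does the reading of a simple acetyl amide, a longer ether chain or a free amine on this carbon.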